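The source may report more compounds than this note shows. Statements on the series, on what has been measured and on what is new or still open speak of the compounds shown alone.

Measured compounds:
- Compound 1 `COc1cc(Cl)cc(-c2nn(-c3cccc(NC(=O)Nc4cccc(C(F)(F)F)c4)c3)cc2-c2ccncc2)c1`, giving 15.5% in a functional assay on HOP-62 cells (Homo sapiens) for inhibition, read by sulforhodamine B assay, with a stated time of 48 h, tested at 10 uM; a lower number here means a stronger effect, a higher number a weaker effect of the compound at the concentration tested
- Compound 2 `COc1cc(Cl)cc(-c2nn(-c3cccc(NC(=O)c4cccc(C(F)(F)F)c4)c3)cc2-c2ccncc2)c1`, giving 71.6%
- Compound 3 `COc1cc(Cl)cc(-c2nn(-c3cccc(NC(=O)Nc4ccc(Cl)c(Cl)c4)c3)cc2-c2ccncc2)c1`, giving 15.7%

Compound 1 stands lowest of the three numbers, which in this assay means the strongest effect at the tested concentration. Compound 3 sits within the scatter of it, while compound 2, which replaces the urea link by an amide, lies far higher: a number 56.1 percentage points higher from compound 1 to compound 2 (beyond the scatter). Changing only the aryl group on the urea nitrogen hardly mattered, as a number 0.2 percentage points higher from compound 1 to compound 3 (within the scatter) shows.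

The unmeasured compound 4 `COc1cc(Cl)cc(-c2nn(-c3cccc(NC(=O)Nc4cc(C(F)(F)F)cc(C(F)(F)F)c4)c3)cc2-c2ccncc2)c1` differs from compound 1 by trifluoromethyl in place of hydrogen on an aromatic carbon, placed on the six-membered aromatic ring of carbon only that already carries a trifluoromethyl group, meta to it. Within the data shown here, the step that bears on this is the one from compound 1 to compound 3, where a different aryl group on the same nitrogen changed nothing beyond the scatter. The urea itself is kept, so a step like that from compound 1 to compound 2 is not expected. For compound 4 the estimate is 18%, between 8% and 34%, so the expected step is a number 2.5 percentage points higher from compound 1 to compound 4 (within the scatter).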

Compound 4, a percentage reported as activity, at one concentration (the size of the read-out at that concentration, not a potency): -41.1%
The estimate for compound 4 lay 59.1 percentage points above the measured number; measured number outside the range, below it.
By their numbers in this assay, from the lowest: compound 4; then compounds 1 and 3 (each within the scatter of the next); then compound 2.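

In this assay, among these compounds, a second trifluoromethyl on the aromatic ring, meta to the first, brings a number 56.6 percentage points lower from compound 1 to compound 4 (beyond the scatter), and compound 4 gives -41.1%, the only negative number among the four compounds. This ring of the urea can therefore matter greatly, which a number 0.2 percentage points higher from compound 1 to compound 3 (within the scatter) did not reveal, and the shift runs opposite to that of the amide link, a number 56.1 percentage points higher from compound 1 to compound 2 (beyond the scatter). Nothing available here explains why this one added group has so large an effect.

The compounds shown leave open whether trifluoromethyl itself is needed at this place or whether a nitrile, a methoxy group or an amine there would give a similar number. They also leave open whether the same addition would have a similar effect in the amide series of compound 2.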